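A few compounds are considered here, and "the series" means these few. Any claim that something is new, unique, unknown or untested is made for them only; others in the source may bear on it.

Compound 1 `CC(C)N(Cc1cccc(OCCCCCC(=O)O)c1)C(=O)c1ccc(-c2ccoc2)cc1`: > 26000 nM
Compound 2 `CCOC(=O)CCCCCOc1cccc(CN(C(=O)c2ccc(-c3cccc(NC(C)=O)c3)cc2)C(C)C)c1`: > 26000 nM
Compound 3 `CCOC(=O)CCCCCOc1cccc(CN(C(=O)c2ccc(-c3cnc(OC)nc3OC)cc2)C(C)C)c1`: > 26000 nM

These three values come from an ADME assay on HEK293 cells (Homo sapiens) for cytotoxicity, read by CellTiter-Glo and resazurin assay, with a stated time of 72 h; on this read-out lower numbers stand for an effect already at smaller amounts and higher numbers for an effect only at larger amounts of compound. Each of the three is a limit of the assay and not a number. Compound 3 stands at that limit, so its place among the measured compounds cannot be told apart from that of the other two. Among the compounds with values here, the one measured step that changes a single group, a step that the two limits leave unreadable from compound 2 to compound 3, likewise cannot be read, because both of its ends sit at the limit (the limit of > 26000 nM in this assay, at which 3 of the 3 values shown sit).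

The next compound, compound 4 `CCOC(=O)CCCCCOc1cccc(CN(C(=O)c2ccc(-c3ccc4[nH]ccc4c3)cc2)C(C)C)c1`, differs from compound 3 by 1H-indol-5-yl in place of 2,4-dimethoxypyrimidin-5-yl on an aromatic carbon.

Within the data shown here, no measured step bears on this change in a readable way; all that the numbers show is that three compounds with different groups at this position stay at the limit. The expectation for compound 4 in this assay is therefore a step that the limit leaves unreadable from compound 3 to compound 4 that is not readable, with a value estimated around 40000 nM, in the range 26000 nM to 100000 nM, most likely again reported only as a limit.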

Compound 4, half-maximal effective concentration: > 26000 nM
Compound 4 gave a limit, no number (the forecaster's own chance of this, stated with the estimate: 85%); the middle value does not contradict the limit.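

Neither new step, from compound 2 or compound 3 to compound 4, can be read, because both ends of each are limits and not numbers: the limit of > 26000 nM in this assay, at which 4 of the 4 values shown sit. The compounds shown leave open whether, in this assay, these groups differ from one another at all.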